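Swapping Bromo for Methoxy: What to Expect of Compound 4

This account rests on a few compounds, and the source may have more. Where it says the series, first, only, none or still open, it means among the compounds named here.

Of the compounds shown here, three sharing one core have been tested in a functional assay on C6 cells (Rattus norvegicus) for cytotoxicity, read by MTT assay, with a stated time of 24 h, tested at 200 ug/mL; on this read-out lower numbers stand for a stronger effect and higher numbers for a weaker effect at the one concentration tested. Compound 1 `O=C(CSc1nnnn1-c1ccccc1)N/N=c1/scc(-c2ccc(Br)cc2)n1-c1ccccc1` gives 20.4% in this assay. Compound 2 `Cc1ccc(-c2cs/c(=N/NC(=O)CSc3nnnn3C)n2-c2ccccc2)cc1` differs from compound 1 in two places at once; in this assay compound 2 gives 39.7%. Compound 3 `O=C(CSc1ncccn1)N/N=c1/scc(-c2ccc(Br)cc2)n1-c1ccccc1` gives 63.2%, the highest of the three numbers and therefore the weakest effect seen here; its nearest neighbour is compound 2 and its furthest is compound 1, both separated from it by more than the scatter. Going by the values given here, the only step measured between compounds that differ in a single place is a number 42.8 percentage points higher from compound 1 to compound 3 (beyond the scatter), and it concerns the group on the sulfur, not the part of the structure altered below.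

Compound 4 `COc1ccc(-c2cs/c(=N/NC(=O)CSc3ncccn3)n2-c2ccccc2)cc1` has not been measured. It differs from compound 3 by methoxy in place of bromo on an aromatic carbon. Among the compounds with values here, no measured step touches this position, so nothing among the tested compounds speaks for or against a shift here. The expectation therefore rests on compound 3 alone: the step is estimated as a number 1.2 percentage points lower from compound 3 to compound 4 (within the scatter), expected to stay within the scatter. Compound 4 is estimated to give 62%, with a range from 40% to 85% kept wide to reflect the absence of any direct comparison.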

Compound 4, a percentage reported as activity, at one concentration (the size of the read-out at that concentration, not a potency): 37.6%
For compound 4 the middle estimate is 24.4 percentage points above the measured one, outside the stated range (below it).
By their numbers in this assay, from the lowest: compound 1; then compounds 4 and 2 (each within the scatter of the next); then compound 3.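

The place on the ring turns out not to be silent: in this assay, the change from 4-bromophenyl to 4-methoxyphenyl gives a number 25.6 percentage points lower from compound 3 to compound 4 (beyond the scatter), which on this read-out means a stronger effect at the one concentration tested. Going by these compounds alone, until now, the only single-place step concerned the group on the sulfur, so this is the first sign that the group on the aromatic carbon, para to a large group, can also move the number by more than the scatter, at least with pyrimidin-2-yl on the sulfur. Nothing available here gives a reason for this shift, and a single step cannot separate the loss of bromo from the gain of methoxy.

The compounds shown leave open whether the same swap would move the number in the same direction with 1-phenyl-1H-tetrazol-5-yl on the sulfur, since this step was read with only one such group. They also do not tell what other groups at this place would do, such as an amine, a carboxylic acid or a longer chain like butoxy.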